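A few compounds are considered here, and "the series" means these few. Any claim that something is new, unique, unknown or untested is made for them only; others in the source may bear on it.

Working notes on the series. Compound 1 `CCOc1cc2nnc(C(N)=O)c(Nc3cc(C)ccc3F)c2cc1N1CCN(C)CC1` is the reference point. In an ADME assay on a cell-free system (plasma) for protein binding (a lower number here means a smaller unbound share, a higher number a larger unbound share of the compound), compound 1 gives 0.11, the highest of the two numbers in hand. For the measured compounds named here, compound 2 `CCOc1cc2nnc(C(N)=O)c(Nc3cccc(Cl)c3F)c2cc1N1CCN(C)CC1` gives 0.019 in this assay, and the only measured step, a 5.8-fold lower number from compound 1 to compound 2 (0.76 log units; beyond the scatter), comes from exchanging one aryl group on the nitrogen for another.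

Compound 3 `COc1cc2nnc(C(N)=O)c(Nc3cc(C)ccc3F)c2cc1N1CCN(C)CC1` is not yet measured. It differs from compound 1 by hydrogen in place of methyl on a saturated chain carbon bound to an oxygen on an aromatic ring, that is, ethoxy becomes methoxy. Going by the values given here, the step from compound 1 to compound 2 changes a different part of the molecule and does not bear on this exchange; no measured step in this set touches the ethoxy group. There is therefore no basis for expecting a step beyond the scatter, and the expected change in this assay is a 1.2-fold higher number from compound 1 to compound 3 (0.07 log units; within the scatter), essentially flat. On that basis compound 3 is estimated at 0.13 in this assay, with a range of 0.07 to 0.25.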

Compound 3, unbound fraction: 0.071
Estimate against measurement, compound 3: 1.8-fold (0.26 log units) above, within the range that was stated.
By their numbers in this assay, from the lowest: compound 2; then compounds 3 and 1 (each within the scatter of the next).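

Ethoxy to methoxy on the core of compound 1 gives the first reading at this position: in this assay the exchange gives a 1.5-fold lower number from compound 1 to compound 3 (0.19 log units; within the scatter) and so stays within the scatter. For the compounds shown here, the exchange of aryl groups on the nitrogen, a 5.8-fold lower number from compound 1 to compound 2 (0.76 log units; beyond the scatter) and beyond the scatter, remains the only step of that kind, and the change from ethyl to methyl on the oxygen does not match it. No measurement on hand bears on the reason for this result.

The compounds shown leave open whether a longer chain such as propoxy, or a branched isopropoxy, on the oxygen would also stay within the scatter of compound 1. They also leave open whether ethoxy to methoxy reads the same with 3-chloro-2-fluorophenyl on the nitrogen.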